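Ring for chain on the ring amine nitrogen substituent

This account rests on a few compounds, and the source may have more. Where it says the series, first, only, none or still open, it means among the compounds named here.

Measured so far:
compound 1 `CC(C)c1nc(C(=O)NCC2CCN(C3CCOCC3)CC2)c2ccccn12` gives 29% in a functional assay on CHO cells for agonist activity at 5-hydroxytryptamine receptor 4 (Homo sapiens), read by a luciferase reporter and cAMP accumulation, with a stated time of 4 h; on this read-out lower numbers stand for smaller maximal responses and higher numbers for larger maximal responses
compound 2 `COCCCN1CCC(O)(CNC(=O)c2nc(C(C)C)n3ccccc23)CC1` gives 41%

Compound 2 stands highest of the two values shown; its nearest neighbour, compound 1, lies below it by a gap beyond the usual scatter. Compound 3 `CC(C)c1nc(C(=O)NCC2(O)CCN(CC3CCOCC3)CC2)c2ccccn12` is not yet measured. It differs from compound 2 in one place: oxan-4-yl in place of 2-methoxyethyl on a saturated chain carbon bound to an amine nitrogen in a ring. Within the data shown here, no single-point step between measured compounds is available to gauge this change, so a modest shift at most is expected, likely none beyond the scatter and if anything downward. Compound 3 is therefore estimated at 36%, between 20% and 55%, an expected step of a number 5 percentage points lower from compound 2 to compound 3 (within the scatter).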

Compound 3, largest response reached (Emax), in percent of the reference or control that the assay uses: 34%
Compound 3: middle estimate off by 2 percentage points, on the high side; the range from low to high includes it.
By their numbers in this assay, from the lowest: compounds 1, 3 and 2 (each within the scatter of the next, the first and the last beyond it).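

In this assay, the change of 2-methoxyethyl to oxan-4-yl on a saturated chain carbon bound to an amine nitrogen in a ring gives a number 7 percentage points lower from compound 2 to compound 3 (within the scatter) and so does not move the maximal response beyond the scatter. At this position, then, an open ether chain and a six-membered ring holding its oxygen are not told apart by this read-out. Nothing at hand bears on why this is so. The compounds shown leave open whether a chain ending in an amine or a carboxylic acid would behave alike here.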